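A few compounds are considered here, and "the series" means these few. Any claim that something is new, unique, unknown or untested is made for them only; others in the source may bear on it.

Among the measured compounds shown here, in a functional assay on HepG2 cells (Homo sapiens) for antiproliferative activity, read by MTT assay, with a stated time of 72 h (a lower number here means a stronger inhibitor, a higher number a weaker inhibitor), three compounds built on the same core have numbers so far. Compound 3 `COc1cc(CCc2ccccc2Cl)cc(OC)c1O` gives 2190 nM, compound 2 `COc1cc(CCc2ccc(F)cc2)cc(OC)c1O` gives 5470 nM and compound 1 `COc1cc(CCc2ccc(Cl)c(Cl)c2)cc(OC)c1O` gives 16100 nM. Compound 2 therefore sits in the middle, with both others beyond the usual scatter from it. Compound 4 `COc1cc(CCc2ccc(Cl)cc2)cc(OC)c1O` differs from compound 2 in one place: chloro in place of fluoro on an aromatic carbon. For the measured compounds named here, no measured pair shows this swap directly. Chloro groups appear on both sides of compound 2, in compound 3 at 2190 nM and in compound 1 at 16100 nM, so only a small rise, within the scatter, is expected in this assay, an estimated 1.2-fold higher number from compound 2 to compound 4 (0.07 log units; within the scatter). For compound 4 the estimated value is 6500 nM, with an expected range of 2500 nM to 15000 nM.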

Compound 4, half-maximal inhibitory concentration: 8780 nM
Beside the measured number, compound 4's estimate is 1.4-fold (0.13 log units) below it; the measured number falls inside the stated range.
By their numbers in this assay, from the lowest: compound 3; then compounds 2, 4 and 1 (each within the scatter of the next, the first and the last beyond it).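

Chloro in place of fluoro on an aromatic carbon, para to a large group, gives a 1.6-fold higher number from compound 2 to compound 4 (0.21 log units; within the scatter) in this assay and so does not separate these two halogens at this position. Hydrogen in place of chloro on an aromatic carbon gives a 1.8-fold lower number from compound 1 to compound 4 (0.26 log units; within the scatter) and likewise stays inside the usual scatter. Nothing available explains either step.

On these data alone, whether a methoxy group, an amine or a carboxylic acid at this position would give a number beyond the scatter from compound 2 stays open.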